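This account rests on a few compounds, and the source may have more. Where it says the series, first, only, none or still open, it means among the compounds named here.

Working notes on the series. Compound 1 `C=C1CC[C@@H]2[C@](C)(CNCc3ccc(C)cc3)[C@H](O)CC[C@@]2(C)[C@@H]1/C=C/C1=CCOC1=O`, compound 2 `C=C1CC[C@@H]2[C@](C)(CNCc3ccc(Br)cc3)[C@H](O)CC[C@@]2(C)[C@@H]1/C=C/C1=CCOC1=O` and compound 3 `C=C1CC[C@@H]2[C@](C)(CNCc3ccc([N+](=O)[O-])cc3)[C@H](O)CC[C@@]2(C)[C@@H]1/C=C/C1=CCOC1=O` share one core and differ only in the group on an aromatic carbon of the amine substituent. In a functional assay on BMMC cells (Mus musculus, strain C57BL/6) for inhibition, with stated times of 5 days and 48 h (a higher number here means a weaker inhibitor, a lower number a stronger inhibitor), compound 1 gives 740 nM, compound 2 gives 430 nM and compound 3 gives 1340 nM. Compound 3 stands highest of the three numbers: a 1.8-fold higher number from compound 1 to compound 3 (0.26 log units; within the scatter) lies within the scatter, while a 3.1-fold higher number from compound 2 to compound 3 (0.49 log units; beyond the scatter) lies beyond it; a 1.7-fold lower number from compound 1 to compound 2 (0.24 log units; within the scatter) is within the scatter.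

Compound 4 `C=C1CC[C@@H]2[C@](C)(CNCc3cccs3)[C@H](O)CC[C@@]2(C)[C@@H]1/C=C/C1=CCOC1=O` carries thiophen-2-yl in place of 4-nitrophenyl on a saturated chain carbon bound to an amine nitrogen. Among the compounds with values here, no measured step exchanges the whole aryl group; the three steps in hand only swap methyl, bromo or nitro on an aromatic carbon. Within the data shown here, what bears on compound 4 is that the nitro compound sits at the top, with only one step, a 3.1-fold higher number from compound 2 to compound 3 (0.49 log units; beyond the scatter), reaching beyond the scatter. Removing the nitro group along with its ring is therefore expected to return the number toward the region of compound 1 and compound 2, a step of about a 1.9-fold lower number from compound 3 to compound 4 (0.28 log units; within the scatter) being the expectation, with low confidence because a 1.8-fold higher number from compound 1 to compound 3 (0.26 log units; within the scatter) is itself within the scatter. Compound 4 is thus estimated at 700 nM in this assay, with an expected range of 300 nM to 1700 nM.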

Compound 4, half-maximal inhibitory concentration: 1070 nM
The estimate for compound 4 lay 1.5-fold (0.18 log units) below the measured number; the measured number falls inside the stated range.
By their numbers in this assay, from the lowest: compounds 2, 1, 4 and 3 (each within the scatter of the next, the first and the last beyond it).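

In this assay, within the data shown here, this change replaces the whole aryl group on a saturated chain carbon bound to an amine nitrogen, whereas the earlier steps only swapped the group on an aromatic carbon. Going from a six-membered aromatic ring of carbon only to a five-membered aromatic ring with 1 hetero atom still leaves compound 4 close to two of its neighbours: a 1.3-fold lower number from compound 3 to compound 4 (0.10 log units; within the scatter) and a 1.4-fold higher number from compound 1 to compound 4 (0.16 log units; within the scatter) both stay inside the usual variation, so the thiophen-2-yl group cannot be told apart from the 4-nitrophenyl or 4-methylphenyl group here. Among these compounds, only a 2.5-fold higher number from compound 2 to compound 4 (0.40 log units; beyond the scatter) is a modest separation, which leaves the 4-bromophenyl group as the one aryl group here that gives a number distinct from that of compound 4, and no supporting data explain this difference.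

From the compounds shown here alone, whether any aromatic ring is needed at this place remains open, and a cyclohexyl ring or a plain butyl chain in the same place would address that. Going by these compounds, it is also open whether a bromo group on the thiophene ring would bring the number toward that of compound 2, or whether pyridin-3-yl would behave as thiophen-2-yl does.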